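This account rests on a few compounds, and the source may have more. Where it says the series, first, only, none or still open, it means among the compounds named here.

Measured compounds:
compound 1 `Oc1ccc(-c2cc(-c3ccccn3)nc(-c3ccccc3Cl)c2)cc1`: 5.2%
compound 2 `Oc1ccc(-c2cc(-c3ccc(Cl)cc3)nc(-c3cccnc3)c2)cc1`: 18.8%
compound 3 `Oc1ccc(-c2cc(-c3cccc(Cl)c3)nc(-c3ccccn3)c2)cc1`: 59.4%

In an assay on isolated protein for inhibition of DNA topoisomerase 1 (Homo sapiens), with a stated time of 30 min, tested at 100 uM (a higher number here means a stronger effect of the compound at the concentration tested, a lower number a weaker effect), compound 3 gives 59.4%, the highest of the three numbers; compound 2 gives 18.8% and compound 1 gives 5.2%, both beyond the scatter below compound 3. Going by the values given here, the only step between compounds differing in one place is a number 54.2 percentage points higher from compound 1 to compound 3 (beyond the scatter), a change of the chlorophenyl group, not of the pyridinyl group. Compound 4 `Oc1ccc(-c2cc(-c3cccnc3)nc(-c3cccc(Cl)c3)c2)cc1` differs from compound 3 by pyridin-3-yl in place of pyridin-2-yl on an aromatic carbon. Among the compounds with values here, no measured step bears directly on this exchange. Compound 2, which carries pyridin-3-yl together with 4-chlorophenyl, gives 18.8%, while compound 3 with pyridin-2-yl and 3-chlorophenyl gives 59.4%; since two places differ between them, their values cannot be separated into a pyridinyl part and a chlorophenyl part. The expectation is accordingly wide. A downward step of a number 24.4 percentage points lower from compound 3 to compound 4 (beyond the scatter) is estimated for the exchange. Compound 4 is expected to give 35%, within a range from 10% to 65%.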

Compound 4, a percentage reported as inhibition, at one concentration (the size of the read-out at that concentration, not a potency): 55.2%
The estimate for compound 4 lay 20.2 percentage points below the measured number; the range from low to high includes it.
By their numbers in this assay, from the lowest: compound 1; then compound 2; then compounds 4 and 3 (each within the scatter of the next).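

In this assay, pyridin-3-yl in place of pyridin-2-yl gives a number 4.2 percentage points lower from compound 3 to compound 4 (within the scatter), so with a 3-chlorophenyl group on the shared core, this exchange of pyridinyl isomers leaves the read-out within the scatter. With pyridin-3-yl held constant, 3-chlorophenyl in place of 4-chlorophenyl gives a number 36.4 percentage points higher from compound 2 to compound 4 (beyond the scatter), which joins the earlier change from 2-chlorophenyl to 3-chlorophenyl, a number 54.2 percentage points higher from compound 1 to compound 3 (beyond the scatter), with pyridin-2-yl held constant: among these pairs, the chlorophenyl isomer changes the number far more than the pyridinyl isomer does. Nothing available explains either the large chlorophenyl steps or the small pyridinyl step.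

On these data alone, whether this position also accepts pyridin-4-yl, an unsubstituted phenyl or a morpholine remains open. So does whether the two chlorophenyl steps would hold for a 3-methoxyphenyl or 3-fluorophenyl group in place of 3-chlorophenyl.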